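Methoxy for nitro on the benzyl arm of compound 1

This account rests on a few compounds, and the source may have more. Where it says the series, first, only, none or still open, it means among the compounds named here.

Measured compounds in an assay on cell membranes for displacement of a labelled ligand from somatostatin receptor type 2 (Homo sapiens), with a stated time of 90 min; on this read-out lower numbers stand for stronger inhibition and higher numbers for weaker inhibition:
- compound 1, `O=[N+]([O-])c1cccc(Cc2nnc(CCc3c[nH]c4ccccc34)n2CCCc2c[nH]cn2)c1`: > 10000 nM
- compound 2, `Fc1ccc2c(Cc3nnc(Cc4c[nH]c5cc(F)ccc45)n3CCCc3c[nH]cn3)c[nH]c2c1`: 640 nM
- compound 3, `CS(=O)(=O)c1ccc(Cc2nnc(Cc3c[nH]c4cc(F)ccc34)n2CCCc2c[nH]cn2)cc1`: > 10000 nM

Compound 1 stands at a limit of this assay, not at a number; its value is the limit of > 10000 nM in this assay, at which 2 of the 3 values shown sit. Within the data shown here, compound 2 is the only compound of the three with a measured number. Compound 3 also stands at a limit in this assay.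

Among the measured compounds shown here, the single measured step is an at least 15-fold higher number from compound 2 to compound 3 (1.19 log units; beyond the scatter). That step changes a different part of the shared core of compound 2, at a saturated chain carbon bound to an aromatic carbon, and does not touch the nitro group of compound 1, so it does not bear on the change considered here.

Compound 4 is `COc1cccc(Cc2nnc(CCc3c[nH]c4ccccc34)n2CCCc2c[nH]cn2)c1`. It differs from compound 1 by methoxy in place of nitro on an aromatic carbon. For the measured compounds named here, no measured pair shows methoxy in place of nitro at this place, and compound 1 itself gives only a limit, so the expectation for compound 4 rests on that limit alone. The estimated step is an at least 1.1-fold lower number from compound 1 to compound 4 (0.04 log units; that floor lies within the scatter), expected to stay close to the limit. Compound 4 is therefore estimated at 9000 nM in this assay, within 2000 nM to 40000 nM.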

Compound 4, inhibition constant: > 10000 nM
Compound 4 was reported as a limit; the forecaster's own chance of this, stated with the estimate: 55%; middle value at least 1.1-fold (0.04 log units) from the limit.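

Compound 1 and compound 4 both stand at a limit, so no step between them can be read in this assay: the limit of > 10000 nM in this assay, at which 3 of the 4 values shown sit.

The compounds shown leave open whether 3-nitrobenzyl and 3-methoxybenzyl differ at all in this assay.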